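The source may hold more compounds than are shown below. What is called first, only, known or untested is meant among the compounds shown, and "the series" means these compounds.

Measured in a functional assay on SW 1116 cells (Homo sapiens) for antiproliferative activity, read by MTT assay, with a stated time of 48 h; on this read-out lower numbers stand for stronger inhibition and higher numbers for weaker inhibition:
Compound 1 `Cc1ccc(N2CCN(Cn3nc(-c4ccc5c(c4)OCCO5)oc3=S)CC2)c(C)c1`: > 50000 nM (a limit)
Compound 2 `COc1ccccc1N1CCN(Cn2nc(-c3ccc4c(c3)OCCO4)oc2=S)CC1`: 16900 nM

In this assay, going by the values given here, compound 2 gives 16900 nM, the only true number so far. Compound 1 gives only a limit, (the limit of > 50000 nM in this assay, at which 1 of the 2 values shown sits). Compound 3 `COc1ccc(N2CCN(Cn3nc(-c4ccc5c(c4)OCCO5)oc3=S)CC2)cc1` has 4-methoxyphenyl in place of 2-methoxyphenyl on an amine nitrogen in a ring. Among the compounds with values here, one measured step bears on this, as it changes the group at the same nitrogen: an at least 2.9-fold lower number from compound 1 to compound 2 (0.47 log units; beyond the scatter). That step shows that this assay responds to this group, but it involves a different group and its size is bounded on one side only. A change of similar or smaller size is therefore expected, with a slight lean towards a higher number and no firm direction. The expected step is a 1.3-fold higher number from compound 2 to compound 3 (0.11 log units; within the scatter). Compound 3 is estimated at 22000 nM, with an expected range of 7000 nM to 50000 nM.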

Compound 3, half-maximal inhibitory concentration: 24200 nM
The estimate for compound 3 lay 1.1-fold (0.04 log units) below the measured number, within the range that was stated.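

In this assay, putting 4-methoxyphenyl in place of 2-methoxyphenyl on the amine nitrogen in the ring gives a 1.4-fold higher number from compound 2 to compound 3 (0.16 log units; within the scatter), so this assay cannot tell the two methoxyphenyl groups apart. The 4-methoxyphenyl group also gives an at least 2.0-fold lower number from compound 1 to compound 3 (0.31 log units; beyond the scatter), which means that compound 1 now stands apart from both methoxyphenyl compounds, not from compound 2 alone. The size of that gap remains bounded on one side only, as compound 1 gives only a limit: the limit of > 50000 nM in this assay, at which 1 of the 3 values shown sits.

What the compounds shown leave open is whether the methoxy group itself matters, or whether a 4-chlorophenyl, 4-hydroxyphenyl or unsubstituted phenyl group on the same nitrogen would read the same. Going by these compounds, it is also open whether a benzyl group there, or any change to the shared core, would give a markedly lower number.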